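A few compounds are considered here, and "the series" means these few. Any claim that something is new, unique, unknown or untested is made for them only; others in the source may bear on it.

Measured so far in an assay on lysate for inhibition of phosphatidylcholine:ceramide cholinephosphotransferase 2 (Homo sapiens), read by HPLC, with stated times of 30 min and 2 h; a lower number here means a stronger inhibitor, a higher number a weaker inhibitor:
compound 1 `O=C(Nc1cccnc1)c1ccccc1OCc1ccccc1` gives 3200 nM
compound 3 `O=C(Nc1cccnc1)c1ccccc1OCc1ccccc1F` gives 3500 nM
compound 2 `O=C(NC1CCCNC1)c1ccccc1OCc1ccccc1Cl` gives > 100000 nM, a limit of the assay and not a number.

Compound 3 sits among the numbers shown next to compound 1, with a 1.1-fold higher number from compound 1 to compound 3 (0.04 log units; within the scatter), so the two are not ordered. Compound 2 reaches (the limit of > 100000 nM in this assay, at which 1 of the 3 values shown sits). Compound 4 `O=C(Nc1cccnc1)c1ccccc1OCc1ccccc1Cl` differs from compound 3 by chloro in place of fluoro on an aromatic carbon. Within the data shown here, only the step from compound 1 to compound 3 bears on a change at this position, and it stayed within the scatter; compound 2 differs from compound 4 in two places, so its limit shows nothing about this single change. Compound 4 is therefore expected to show no change at the digits printed from compound 3 to compound 4 (within the scatter), no step beyond the scatter in this assay. The estimate for compound 4 is 3500 nM, within 1500 nM to 9000 nM.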

Compound 4, half-maximal inhibitory concentration: 1100 nM
Estimate against measurement, compound 4: 3.2-fold (0.50 log units) above; the measured number lies below the stated range.
By their numbers in this assay, from the lowest: compound 4; then compounds 1 and 3 (each within the scatter of the next). At a limit, above all of these: compound 2.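

The change from 2-fluorophenyl to 2-chlorophenyl does move the number (a 3.2-fold lower number from compound 3 to compound 4 (0.50 log units; beyond the scatter)), and chloro also stands apart from hydrogen (a 2.9-fold lower number from compound 1 to compound 4 (0.46 log units; beyond the scatter)), whereas fluoro did not, so this place on the ring is not indifferent to what it carries. On the amide-type nitrogen, pyridin-3-yl in place of piperidin-3-yl gives a far larger step (an at least 90-fold lower number from compound 2 to compound 4 (1.95 log units; beyond the scatter)). The value of compound 2 is a limit of the assay and not a number: the limit of > 100000 nM in this assay, at which 1 of the 4 values shown sits.

Going by these compounds, whether bromo, methyl or methoxy at this place would go beyond chloro stays open. So does whether chloro elsewhere on this ring gives the same step.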